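Swapping the aryl group on the thiazolidinone nitrogen

The source may report more compounds than this note shows. Statements on the series, on what has been measured and on what is new or still open speak of the compounds shown alone.

Compound 1 `COc1ccc(C)cc1N1C(=O)CSC1c1cccc(C(=O)NCCCCc2ccccc2)c1`: 95%
Compound 2 `COc1ccc(F)cc1N1C(=O)CSC1c1cccc(C(=O)NCCCCc2ccccc2)c1`: 95%

In a functional assay on HOS-TE85 cells (Homo sapiens) for inhibition, read by CCK-8 assay, with a stated time of 72 h, tested at 1 uM (on this read-out higher numbers stand for more inhibition at the one concentration tested (going by the name of the read-out) and lower numbers for less inhibition), compound 1 gives 95%. In this assay compound 2 gives 95%. For the measured compounds named here, the one measured step, no change at the digits printed from compound 1 to compound 2 (within the scatter), is fluoro in place of methyl on an aromatic carbon, and it left the read-out where it was. Compound 2 thus stands level with compound 1, and nothing in the measured pair separates the two.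

Compound 3 `COc1ccc(N2C(=O)CSC2c2cccc(C(=O)NCCCCc3ccccc3)c2)c(OC)c1` has not yet been tested. It differs from compound 2 in this way: 2,4-dimethoxyphenyl in place of 5-fluoro-2-methoxyphenyl on an amide-type nitrogen in a ring. Going by the values given here, the single measured step bears on it only loosely, since it too alters a group on the ring that sits on the amide-type nitrogen in a ring of the shared core, and that step was flat within the scatter. Among the compounds with values here, no step that exchanges the whole aryl group, or that adds a second methoxy, is available. On that basis the expected step of a number 5 percentage points lower from compound 2 to compound 3 (within the scatter) is none beyond the scatter, with the read-out already near its ceiling. For compound 3 the estimate in this assay is therefore 90%, with a range from 72% to 98%.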

Compound 3, a percentage reported as inhibition, at one concentration (the size of the read-out at that concentration, not a potency): 58%
The estimate for compound 3 lay 32 percentage points above the measured number, and the stated range ends above it.
By their numbers in this assay, from the lowest: compound 3; then compounds 1 and 2 (each within the scatter of the next).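

In this assay, the aryl group on the amide-type nitrogen in a ring turned out not to be free to vary: 2,4-dimethoxyphenyl in place of 5-fluoro-2-methoxyphenyl brought a number 37 percentage points lower from compound 2 to compound 3 (beyond the scatter), and the same group in place of 2-methoxy-5-methylphenyl brought a number 37 percentage points lower from compound 1 to compound 3 (beyond the scatter). The earlier exchange of methyl for fluoro had shown only that these two groups read alike, whereas this result shows that the read-out at this position can fall well away from its high level. The exchange alters both the identity of the second substituent and where it is named on the phenyl ring, so the drop cannot be assigned to either alone, and nothing measured here explains it.

Still open, on these data alone, is whether the loss goes with the second methoxy group itself or with its place on the ring, which a 2,5-dimethoxyphenyl or a 4-fluoro-2-methoxyphenyl group on the same nitrogen would separate. Also open, as far as these compounds go, is how a plain phenyl group, or a 4-chloro-2-methoxyphenyl group, would read at this position.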